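The source may hold more compounds than are shown below. What is called first, only, known or untested is meant among the compounds shown, and "the series" means these compounds.

Measured so far in an ADME assay on microsomes from liver (Mus musculus) for metabolic stability, with a stated time of 30 min; a lower number here means that less of the compound is left, a higher number that more of the compound is left:
compound 1 `CCCCc1nc(C)c(CC(=O)OC)c(=O)n1Cc1ccc(-c2ccccc2-c2noc(=O)[nH]2)cc1` gives 47.1%
compound 2 `CCCCc1nc(C)c(CC(=O)OC2CC2)c(=O)n1Cc1ccc(-c2ccccc2-c2noc(=O)[nH]2)cc1` gives 12.8%

Compound 2 stands lowest of the two numbers in this assay; its nearest neighbour is compound 1, which gives 47.1%. For the measured compounds named here, the one measured step at the ester oxygen is a number 34.3 percentage points lower from compound 1 to compound 2 (beyond the scatter), a large fall beyond the scatter.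

Compound 3 `CCCCc1nc(C)c(CC(=O)OC2CCCCC2)c(=O)n1Cc1ccc(-c2ccccc2-c2noc(=O)[nH]2)cc1` differs from compound 2 by cyclohexyl in place of cyclopropyl on an oxygen next to a carbonyl group. The change sits at the same place where the step from compound 1 to compound 2 was taken, and that step is the only measured one that bears on it. It ran from the smaller to the larger group on this oxygen and the number fell sharply. A further enlargement of the group at the same oxygen is therefore expected to keep the number low; a step of a number 3.8 percentage points lower from compound 2 to compound 3 (within the scatter) is expected, small in size. Compound 3 is expected to give 9%, with a range from 2% to 28%.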

Compound 3, percent of the compound remaining: 10.7%
Compound 3: the middle estimate sits 1.7 percentage points below what was measured; measured number inside the range.
By their numbers in this assay, from the lowest: compounds 3 and 2 (each within the scatter of the next); then compound 1.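

In this assay, the oxygen next to a carbonyl group now carries three measured groups, and cyclohexyl in place of cyclopropyl gives a number 2.1 percentage points lower from compound 2 to compound 3 (within the scatter), so the two rings cannot be told apart at this position. Cyclohexyl in place of methyl gives a number 36.4 percentage points lower from compound 1 to compound 3 (beyond the scatter), so the large fall first seen with cyclopropyl also appears with a second, larger ring, and compound 1 alone stands clear of the other two. Nothing measured here gives a reason for either step.

From the compounds shown here alone, whether an open chain on this oxygen, such as isopropyl or n-butyl, would read with methyl or with the two rings remains open. Also open, going by these compounds, is how a carboxylic acid or an amide in place of the ester would read in this assay.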